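Methyl for benzyloxycarbonyl on sulfur: expected step from compound 1

The source may hold more compounds than are shown below. What is called first, only, known or untested is meant among the compounds shown, and "the series" means these compounds.

In a functional assay on MCF7 cells (Homo sapiens) for inhibition, read by MTT assay, with a stated time of 96 h (on this read-out lower numbers stand for stronger inhibition of growth and higher numbers for weaker inhibition of growth), compound 1 `O=C(OCc1ccccc1)SCCCCCCNC(=O)c1cc(-c2ccncc2)n[nH]1` gives 8370 nM and compound 2 `O=C(NCCCCCCS)c1cc(-c2c[nH]c3ccccc23)n[nH]1` gives 18200 nM. Compound 1 thus holds the lower of these two numbers, with a gap beyond the scatter. Compound 3 `O=C(NCCCCCCS)c1cc(C2CCCCC2)n[nH]1` gives > 50000 nM, which is a limit of the assay. Compound 4 `CSCCCCCCNC(=O)c1cc(-c2ccncc2)n[nH]1` carries methyl in place of benzyloxycarbonyl on a sulfur. Going by the values given here, no measured pair tests this change directly. A step towards a higher number in this assay, beyond the scatter, is expected. That direction rests only loosely on the higher number of compound 2 at 18200 nM. The expected step is a 3.3-fold higher number from compound 1 to compound 4 (0.52 log units; beyond the scatter). For compound 4 the estimate is 28000 nM, with an expected range from 11000 nM to 50000 nM.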

Compound 4, concentration for 50% growth inhibition: > 50000 nM
Compound 4 was reported as a limit; the forecaster's own chance of this, stated with the estimate: 35%; middle value at least 1.7-fold (0.25 log units) away from the limit.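

Benzyloxycarbonyl on the sulfur now has a direct reading in this assay: with the rest of the structure unchanged, methyl in its place gives an at least 5.9-fold higher number from compound 1 to compound 4 (0.77 log units; beyond the scatter). For compound 4, > 50000 nM is a limit of the assay. The true size of the step therefore stays unresolved, and only its lower bound can be read: the limit of > 50000 nM in this assay, at which 2 of the 4 values shown sit.

Open, as far as these compounds go, is whether the whole benzyloxycarbonyl group is needed or only part of it. A benzyl or an acetyl group on this sulfur would separate those two readings.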